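The compounds below may be only part of what the source reports. "The series", "measured", "known", "first", "only" and "open" are said of these compounds alone.

Measured in an ADME assay (liver) for metabolic stability, with Liver microsome (Rattus norvegicus) as the target, using microsomes and NADPH, with a stated time of 30 min; on this read-out lower numbers stand for slow clearance and higher numbers for fast clearance:
- compound 1 `CC#C[C@H]1CN(S(=O)(=O)c2ccc(N)nc2)CCN1c1ccc([C@@](O)(CO)C(F)(F)F)cc1`: 53 mL.min-1.g-1
- compound 2 `CC#C[C@H]1CN(S(=O)(=O)c2ccc(N)nc2)CCN1c1ccc(S(N)(=O)=O)cc1`: 30 mL.min-1.g-1
- compound 3 `CC#C[C@H]1CN(S(=O)(=O)c2ccc(N)nc2)CCN1c1ccc(S(C)(=N)=O)cc1`: < 14 mL.min-1.g-1

Compound 3 reads < 14 mL.min-1.g-1, which is a limit of the assay and not a number. It still stands lowest of the three, with an at least 3.7-fold lower number from compound 1 to compound 3 (0.57 log units; beyond the scatter) and an at least 2.1-fold lower number from compound 2 to compound 3 (0.33 log units; beyond the scatter), both beyond the scatter. The remaining pair, a 1.8-fold lower number from compound 1 to compound 2 (0.25 log units; within the scatter), stays within the scatter.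

Compound 4 `CC#C[C@H]1CN(S(=O)(=O)c2ccc(N)nc2)CCN1c1ccc(S(=N)(=O)C2CC2)cc1` carries cyclopropyl in place of methyl on a sulfinyl sulfur. Within the data shown here, no measured step makes this change. The three steps above all exchange the whole group on the aromatic carbon, so they bear on it only indirectly, and they show that this assay can move by a modest amount when that group changes.

A modest rise in this assay is therefore expected, though a result that again reaches the limit remains possible. The expected change is an at least 1.3-fold higher number from compound 3 to compound 4 (0.13 log units; that floor lies within the scatter). For compound 4 the estimated value is 19 mL.min-1.g-1, with an expected range from 9 mL.min-1.g-1 to 40 mL.min-1.g-1.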

Compound 4, intrinsic clearance in microsomes: 23 mL.min-1.g-1
Estimate against measurement, compound 4: 1.2-fold (0.08 log units) below; low and high end bracket the measured number.
By their numbers in this assay, from the lowest: compounds 4, 2 and 1 (each within the scatter of the next, the first and the last beyond it). At a limit, below all of these: compound 3.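

Cyclopropyl in place of methyl on a sulfinyl sulfur now has a direct reading in this assay: an at least 1.6-fold higher number from compound 3 to compound 4 (0.21 log units; that floor lies within the scatter). This step is a floor and not a full size because compound 3 stands at a limit: the limit of < 14 mL.min-1.g-1 in this assay, at which 1 of the 4 values shown sits. Set against the other groups on the aromatic carbon, the new reading gives a 1.3-fold lower number from compound 2 to compound 4 (0.12 log units; within the scatter), which leaves those two compounds unseparated, and a 2.3-fold lower number from compound 1 to compound 4 (0.36 log units; beyond the scatter), a modest step.

On these data alone, it remains open whether the ring itself matters or only the added carbon, and an ethyl or isopropyl group on the sulfinyl sulfur would tell these apart. As far as these compounds go, it is also open whether cyclopropyl in place of methyl reads the same way on another core.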